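Aryloxy-benzimidazole benzoic acids: pyridyl ether permeability notes

The source may report more compounds than this note shows. Statements on the series, on what has been measured and on what is new or still open speak of the compounds shown alone.

Two members of the series carry a measurement in an ADME assay for permeability, using PAMPA, with a stated time of 4 h; on this read-out lower numbers stand for lower permeability and higher numbers for higher permeability. Compound 1 `Cn1c(COc2cccc(C(=O)O)c2)nc2cnc(Oc3ccc4c(c3)CCC4)cc21` gives 16.5 10^-6 cm/s in this assay. Compound 2 `Cn1c(COc2cccc(C(=O)O)c2)nc2ccc(Oc3cccc(Cl)n3)cc21` gives 7.6 10^-6 cm/s in this assay, the lower of the two numbers, and the gap to compound 1 lies beyond the scatter. For the measured compounds named here, compound 2 and compound 1 differ in more than one place, so their two values show only that the numbers part; no single step between them is computed.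

The next step keeps the shared core and the benzoic acid ether of compound 2 and changes only the pyridyl ether: compound 3 `Cn1c(COc2cccc(C(=O)O)c2)nc2ccc(Oc3ncc(Cl)cc3F)cc21` carries 5-chloro-3-fluoropyridin-2-yl in place of 6-chloropyridin-2-yl on an oxygen on an aromatic ring. The change from (6-chloropyridin-2-yl)oxy to (5-chloro-3-fluoropyridin-2-yl)oxy leaves the counts of hydrogen-bond donors and acceptors as they stand. Going by the values given here, with no measured pair isolating this kind of change, the expected step of a 1.2-fold higher number from compound 2 to compound 3 (0.07 log units; within the scatter) is small, within the scatter, with no clear direction. Compound 3 is therefore estimated at 9 10^-6 cm/s in this assay, with a range from 4 10^-6 cm/s to 20 10^-6 cm/s.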

Compound 3, apparent permeability: 11.8 10^-6 cm/s
Estimate against measurement, compound 3: 1.3-fold (0.12 log units) below, and the stated range covers the measured number.
By their numbers in this assay, from the lowest: compounds 2, 3 and 1 (each within the scatter of the next, the first and the last beyond it).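

On an oxygen on an aromatic ring, 5-chloro-3-fluoropyridin-2-yl in place of 6-chloropyridin-2-yl gives the series its first reading of a change in one place: in this assay the result is a 1.6-fold higher number from compound 2 to compound 3 (0.19 log units; within the scatter), so this swap does not separate the two compounds on this read-out. The swap adds a fluorine, taking the group from 7 to 8 heavy atoms, and alters the substitution pattern of the chloropyridine, while the counts of hydrogen-bond donors and acceptors stay as they were and the ring remains a six-membered aromatic ring with 1 hetero atom. Nothing available bears on why the read-out responds in this way.

This single step carries the fluorine and the altered chlorine pattern together, so the compounds shown do not assign any share of it to either, and they leave open how a pyridyl ether bearing an amine, a nitrile or a methoxy group would read. Compound 1 differs from compound 2 and compound 3 in more than one place. For the compounds shown here, no single step between compound 1 and either of those compounds can be read.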